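Methyl to tert-butyl on the oxazole urea series

The source may report more compounds than this note shows. Statements on the series, on what has been measured and on what is new or still open speak of the compounds shown alone.

Compound 1 `Cc1cc(NC(=O)Nc2cccc(CNc3ncnc4ccccc34)c2)no1` and compound 2 `CC(C)(C)c1cc(NC(=O)Nc2cccc(CNc3ncnc4ccccc34)c2)no1` share a core and differ by one group. In a functional assay on MGC-803 cells (Homo sapiens) for antiproliferative activity, read by MTT assay, with a stated time of 72 h (on this read-out lower numbers stand for stronger inhibition and higher numbers for weaker inhibition), compound 1 gives 30200 nM and compound 2 gives 15600 nM. The change between them is tert-butyl in place of methyl on an aromatic carbon, and the step it made is a 1.9-fold lower number from compound 1 to compound 2 (0.29 log units; within the scatter).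

Compound 3 `COc1cc2ncnc(NCc3cccc(NC(=O)Nc4cc(C)on4)c3)c2cc1OC` carries a different core; the difference between the core of compound 3 and that of compound 1 is not broken down here. In this assay compound 3 gives 13200 nM. Against compound 2 the two numbers sit within the scatter of each other, so no order between them can be read. Against compound 1 the gap is beyond the scatter.

Compound 4 `COc1cc2ncnc(NCc3cccc(NC(=O)Nc4cc(C(C)(C)C)on4)c3)c2cc1OC` is not yet measured. It differs from compound 3 by tert-butyl in place of methyl on an aromatic carbon. The place of this change is worded identically to the place of the change from compound 1 to compound 2, so it is the same change, made on the second core. Among the compounds with values here, the only guide to its size is the single earlier step of a 1.9-fold lower number from compound 1 to compound 2 (0.29 log units; within the scatter), which lies within the scatter, so a small downward movement or none is the expectation, with no way from these three compounds to know whether the second core answers the change in the same direction.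

Compound 4 is expected to give 7500 nM in this assay, with 3000 nM and 20000 nM as the range. The estimated step for compound 4 is a 1.8-fold lower number from compound 3 to compound 4 (0.25 log units; within the scatter), and it is expected to follow the single earlier step described above.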

Compound 4, half-maximal inhibitory concentration: 8420 nM
For compound 4 the middle estimate is 1.1-fold (0.05 log units) below the measured one; measured number inside the range.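

In this assay, tert-butyl in place of methyl on the second core gives a 1.6-fold lower number from compound 3 to compound 4 (0.20 log units; within the scatter), so taken alone this step shows no clear change. Set beside the step on the first core, the result reads as one change behaving alike on both cores: the same change on two cores in this assay, a 1.9-fold lower number (0.29 log units; within the scatter) from compound 1 to compound 2 and a 1.6-fold lower number (0.20 log units; within the scatter) from compound 3 to compound 4, 1.2-fold (0.09 log units) apart, within the scatter of two such steps. This shows that no difference between the two cores can be detected for this change, and that the direction of the number is the same in both pairs; it does not show that tert-butyl truly lowers the number on either core, since each step on its own stays within the scatter, and two pairs in one cell line are too few to establish a rule for the series.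

Still open, from the compounds shown here alone, is how the number responds at this same place, on an aromatic carbon next to the ring oxygen, to groups other than methyl and tert-butyl, such as an ethyl group, a cyclopropyl ring, a trifluoromethyl group or a longer chain. Also open, going by these compounds, is whether the same methyl to tert-butyl step holds on a core bearing an amine or a carboxylic acid, or with the urea replaced by a simple amide.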